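From Compound 3 to Compound 4: a Shorter Side Chain

The source may report more compounds than this note shows. Statements on the series, on what has been measured and on what is new or still open speak of the compounds shown alone.

Of the compounds shown here, three have been measured in a functional assay on PBMC cells (Homo sapiens) for inhibition; a lower number here means a stronger inhibitor, a higher number a weaker inhibitor. Compound 1 `N=C(N)NCCC[C@H](N)C(=O)NS(=O)(=O)OC[C@H]1OC[C@@H](n2cnc3c(N)ncnc32)C[C@@H]1O` gives 600 nM in this assay. Compound 2 `CSCC[C@H](N)C(=O)NS(=O)(=O)OC[C@H]1OC[C@@H](n2cnc3c(N)ncnc32)[C@H](O)[C@@H]1O` gives 5200 nM. Compound 3 `CC(C)C[C@H](N)C(=O)NS(=O)(=O)OC[C@H]1O[C@@H](n2cnc3c(N)ncnc32)[C@H](O)[C@@H]1O` gives 1100 nM, the second highest of the three numbers; its nearest neighbour is compound 1, whose number lies within the usual scatter of it, while compound 2 stands furthest away, beyond the scatter.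

Compound 4 `CC(C)[C@H](N)C(=O)NS(=O)(=O)OC[C@H]1O[C@@H](n2cnc3c(N)ncnc32)[C@H](O)[C@@H]1O` differs from compound 3 in one place: isopropyl in place of isobutyl on a saturated chain carbon bound to an amine nitrogen and a carbonyl carbon. Going by the values given here, no pair of measured compounds shows this change, so there is no measured step to guide the expectation. A change of one chain carbon at this position is expected to move the number only a little, if at all beyond the scatter, and if it moves, more likely toward a weaker inhibitor. Compound 4 is therefore expected to give about 1600 nM, within a range from 600 nM to 4500 nM. This amounts to an expected step of a 1.5-fold higher number from compound 3 to compound 4 (0.16 log units; within the scatter).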

Compound 4, half-maximal inhibitory concentration: 5600 nM
Compound 4: middle estimate off by 3.5-fold (0.54 log units), on the low side; measured number outside the range, above it.
By their numbers in this assay, from the lowest: compounds 1 and 3 (each within the scatter of the next); then compounds 2 and 4 (each within the scatter of the next).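

In this assay, isopropyl in place of isobutyl on a saturated chain carbon bound to an amine nitrogen and a carbonyl carbon gives a 5.1-fold higher number from compound 3 to compound 4 (0.71 log units; beyond the scatter) and so lies beyond the scatter. Going by these compounds alone, this is the only measured step at this position, and it shows that the number responds to the loss of a single chain carbon, toward a weaker inhibitor. Nothing available accounts for the size of this step.

The compounds shown leave open whether a straight butyl chain, a cyclohexyl group or a carboxylic acid at this position would move the number further in either direction. They also leave open whether the same change would give a step of similar size on the core of compound 1, which differs from compound 3 in more than one place.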